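The source may hold more compounds than are shown below. What is called first, only, known or untested is meant among the compounds shown, and "the series" means these compounds.

Three compounds share one core and differ only in the aromatic group attached to the five-membered ring. Compound 1 `CC1CCC(C(C)C)C(O[C@H]2OC(=O)C(Br)=C2Sc2nnc(-c3ccc(Cl)cc3)s2)C1` carries a 4-chlorophenyl group, compound 2 `CC1CCC(C(C)C)C(O[C@H]2OC(=O)C(Br)=C2Sc2nnc(-c3ccc(O)cc3)s2)C1` a 4-hydroxyphenyl group, and compound 3 `CC1CCC(C(C)C)C(O[C@H]2OC(=O)C(Br)=C2Sc2nnc(-c3ccncc3)s2)C1` a pyridin-4-yl group. In a functional assay on HeLa cells (Homo sapiens) for antiproliferative activity, read by MTT assay, with a stated time of 24 h (on this read-out lower numbers stand for stronger inhibition and higher numbers for weaker inhibition), compound 1 gives 2200 nM, compound 2 gives 2600 nM, and compound 3 gives 1300 nM. The number for compound 3 is the smallest of the three, yet a 1.7-fold lower number from compound 1 to compound 3 (0.23 log units; within the scatter) and a 2.0-fold lower number from compound 2 to compound 3 (0.30 log units; within the scatter) both lie within the scatter, as does a 1.2-fold higher number from compound 1 to compound 2 (0.07 log units; within the scatter), so the three compounds cannot be told apart on this read-out.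

Compound 4 `CC1CCC(C(C)C)C(O[C@H]2OC(=O)C(Br)=C2Sc2nnc(-c3cccnc3)s2)C1` has not been measured. It differs from compound 3 by pyridin-3-yl in place of pyridin-4-yl on an aromatic carbon; the two have the same atoms, joined differently, and the group sits on an aromatic carbon of a five-membered aromatic ring with 2 nitrogen and 1 sulfur. Within the data shown here, no measured pair swaps one pyridine attachment for another, so no step bears on this change directly. All three measured changes at this position stayed within the scatter, which gives no reason to expect a step beyond it here. Compound 4 is therefore expected to show a 1.2-fold higher number from compound 3 to compound 4 (0.06 log units; within the scatter), with an estimate of 1500 nM, ranging from 700 nM to 3200 nM.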

Compound 4, half-maximal inhibitory concentration: 5600 nM
Estimate against measurement, compound 4: 3.7-fold (0.57 log units) below; the measured number lies above the stated range.
By their numbers in this assay, from the lowest: compounds 3, 1 and 2 (each within the scatter of the next); then compound 4.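

Until now every change at this position stayed within the scatter, so the position seemed not to distinguish among the aromatic groups it carried. In this assay there is now a 4.3-fold higher number from compound 3 to compound 4 (0.63 log units; beyond the scatter) and this first step beyond the scatter comes from a change that keeps the same atoms and only joins them differently. Compound 4 also separates from the two compounds with a substituted phenyl group, showing a 2.2-fold higher number from compound 2 to compound 4 (0.33 log units; beyond the scatter) and a 2.5-fold higher number from compound 1 to compound 4 (0.41 log units; beyond the scatter) so the position does respond to the group placed on it, although all three steps are modest, and no available evidence explains why pyridin-3-yl and pyridin-4-yl differ here.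

The compounds shown leave open whether pyridin-2-yl would fall with compound 3 or with compound 4, so two pyridine attachments cannot yet define a trend. They also leave open whether a phenyl group carrying an amine or a carboxylic acid would stay with compounds 1, 2 and 3 or move away from them as compound 4 does.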